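A few compounds are considered here, and "the series" means these few. Any claim that something is new, unique, unknown or untested is made for them only; others in the source may bear on it.

Measured in a functional assay on K562 cells (Homo sapiens), read by MTT assay, with a stated time of 72 h; on this read-out higher numbers stand for weaker inhibition and lower numbers for stronger inhibition:
Compound 1 `CNc1ncnc2c1c(-c1cccs1)cn2[C@@H]1O[C@H](CO)[C@@H](O)[C@H]1O`: > 20000 nM, a limit
Compound 2 `Nc1nc(N)c2c(-c3ccco3)cn([C@@H]3O[C@H](CO)[C@@H](O)[C@H]3O)c2n1`: > 20000 nM, a limit
Compound 3 `Cc1nc(N)c2c(-c3ccco3)cn([C@@H]3O[C@H](CO)[C@@H](O)[C@H]3O)c2n1`: > 20000 nM, a limit

Compound 3 has no numerical value in this assay, only the limit > 20000 nM. It shares this position with the other two compounds: the limit of > 20000 nM in this assay, at which 3 of the 3 values shown sit.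

Compound 4 `Cc1nc(N)c2c(-c3cc4ccccc4o3)cn([C@@H]3O[C@H](CO)[C@@H](O)[C@H]3O)c2n1` has 1-benzofuran-2-yl in place of furan-2-yl on an aromatic carbon of compound 3: 1-benzofuran-2-yl in place of furan-2-yl on an aromatic carbon. Among the compounds with values here, the one measured step, a step that the two limits leave unreadable from compound 2 to compound 3, is a different change, methyl in place of amino on an aromatic carbon, and it has no readable size. Within the data shown here, no measured step replaces furan-2-yl, so the data give neither a size nor a direction for this change.

The expectation therefore rests on the shared limit, (the limit of > 20000 nM in this assay, at which 3 of the 3 values shown sit). Compound 4 is expected to stay at this limit too, although a measurable number cannot be ruled out. No change beyond the usual scatter is expected for the estimated step, a number no higher from compound 3 to compound 4 (the limit leaves the size open). Compound 4 is estimated at 20000 nM, with an expected range from 6000 nM to 40000 nM.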

Compound 4, half-maximal inhibitory concentration: 15700 nM
Beside the measured number, compound 4's estimate is 1.3-fold (0.11 log units) above it; the measured number falls inside the stated range.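

In this assay, compound 4 gives the first reading among the compounds shown that is a number rather than a limit, so this aromatic carbon of the five-membered ring can carry a group that yields a measurable value. On these data alone, replacing furan-2-yl with 1-benzofuran-2-yl, which adds a six-membered aromatic ring of carbon only, gives an at least 1.2-fold lower number from compound 3 to compound 4 (0.10 log units; that floor lies within the scatter); the value of compound 3 is a limit, so the true size stays open and the step does not establish a change beyond the scatter. The other step, methyl in place of amino, cannot be read, and the series as a whole remains tied to one limit: the limit of > 20000 nM in this assay, at which 3 of the 4 values shown sit.

The compounds shown leave open whether 1-benzofuran-2-yl would still give a number with amino in place of methyl on the shared core, or with the methylamino pattern of compound 1. They also leave open whether a different group at this position, such as phenyl, naphthalen-2-yl or a furan-2-yl bearing an aminomethyl chain, would give a number clearly separated from this limit.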